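Chain length and amine swap at the aryl ether tail

The source may report more compounds than this note shows. Statements on the series, on what has been measured and on what is new or still open speak of the compounds shown alone.

Compound 1 `COc1cc(/C=C/C(=O)Nc2ccccc2)ccc1OCCCCN1CCCCC1`: 1.61
Compound 2 `COc1cc(/C=C/C(=O)Nc2ccccc2)ccc1OCCCCCCN1CCCCC1`: 1.77
Compound 3 `COc1cc(/C=C/C(=O)Nc2ccccc2)ccc1OCCCCCCCCN(C)C`: 1.74

In a physicochemical assay for lipophilicity, using the shake flask method, measured as octanol-water partition, at pH 7.4 (on this read-out higher numbers stand for higher lipophilicity and lower numbers for lower lipophilicity), compound 3 stands second highest of the three numbers, though neither gap is telling: a number 0.03 log units lower from compound 2 to compound 3 (within the scatter) and a number 0.13 log units higher from compound 1 to compound 3 (within the scatter) both lie within the scatter. Compound 4 `COc1cc(/C=C/C(=O)Nc2ccccc2)ccc1OCCCCCCCCCCN1CCCC1` differs from compound 3 by 2-(pyrrolidin-1-yl)ethyl in place of dimethylamino on a saturated chain carbon, eight bonds along the chain from an oxygen on an aromatic ring. All three measured steps bear on this kind of change, each combining a longer chain with a different terminal amine: a number 0.16 log units higher from compound 1 to compound 2 (within the scatter), a number 0.13 log units higher from compound 1 to compound 3 (within the scatter) and a number 0.03 log units lower from compound 2 to compound 3 (within the scatter). None of them moved this assay beyond the scatter, and the largest, from compound 1 to compound 2, is the one that adds chain carbons while keeping a ring amine. Compound 4 adds more chain carbons than any of those steps and also brings in a ring, so a small rise is expected, a number 0.21 log units higher from compound 3 to compound 4 (within the scatter), most likely within or just at the edge of the scatter. The expected value for compound 4 in this assay is 1.95, with a range from 1.6 to 2.35.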

Compound 4, partition coefficient: 1.86
For compound 4 the middle estimate is 0.09 log units above the measured one; low and high end bracket the measured number.
By their numbers in this assay, from the lowest: compounds 1, 3, 2 and 4 (each within the scatter of the next).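

In this assay, compound 4, with its 2-(pyrrolidin-1-yl)ethyl end, stays within the scatter of all three earlier compounds: a number 0.12 log units higher from compound 3 to compound 4 (within the scatter), a number 0.09 log units higher from compound 2 to compound 4 (within the scatter) and a number 0.25 log units higher from compound 1 to compound 4 (within the scatter). The last of these, 6-(pyrrolidin-1-yl)hexyl in place of piperidin-1-yl, is the widest step shown, yet even it does not leave the scatter, so a five-membered non-aromatic ring on this chain does not set compound 4 apart from the others. No measurement offered here accounts for these small steps.

Each step to compound 4 alters the chain and the terminal amine together, so these steps cannot part the two changes. From the compounds shown here alone, whether a morpholine ring, a terminal carboxylic acid or a longer chain would carry the number beyond the scatter remains open.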